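The compounds below may be only part of what the source reports. "The series", "measured", "known", "first", "only" and "open" are said of these compounds alone.

In an ADME assay on the whole organism (Rattus norvegicus) for pharmacokinetics, read by HPLC, at a dose of 3 mg/kg by the oral route (a higher number here means more compound in the circulation at the dose given, a lower number less compound in the circulation), compound 2 `N#Cc1cc(C(=O)N2CS(=O)(=O)c3ccccc32)cc(C2CC2)c1O` gives 10800 nM. Among the compounds with values here, compound 3 `N#Cc1cc(C(=O)N2CSc3ccccc32)cc(C(F)(F)F)c1O` gives 8990 nM, a number within the usual scatter of the one for compound 2. Within the data shown here, compound 1 `N#Cc1cc(C(=O)N2CCc3ccccc32)cc(C2CC2)c1O` gives 4470 nM, and the gap between that number and the one for compound 2 is beyond the scatter. Compound 2 therefore stands clear of compound 1 but cannot be told apart from compound 3.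

The next compound, compound 4 `CSc1cc(C(=O)N2CS(=O)(=O)c3ccccc32)cc(C#N)c1O`, differs from compound 2 in one group: methylsulfanyl in place of cyclopropyl on an aromatic carbon, ortho to a hydroxy group (methylsulfanyl in place of cyclopropyl on an aromatic carbon). Among the measured compounds shown here, no two measured compounds differ by this exchange, so the data offer only a loose guide to its effect. Compound 1 at 4470 nM and compound 2 at 10800 nM mark the span seen so far, and nothing points to a step larger than that span. A modest fall in this assay is the expectation. The estimated step of a 1.5-fold lower number from compound 2 to compound 4 (0.19 log units; within the scatter) is small and is expected to stay within the scatter. For compound 4 the maximal plasma concentration is estimated at 7000 nM, with an expected range of 2500 nM to 15000 nM.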

Compound 4, maximal plasma concentration: 3000 nM
Beside the measured number, compound 4's estimate is 2.3-fold (0.37 log units) above it; the measured number falls inside the stated range.
By their numbers in this assay, from the lowest: compounds 4, 1, 3 and 2 (each within the scatter of the next, the first and the last beyond it).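

Within the data shown here, this is the first pair in the set that differs in one place only, so it gives the first direct reading of a single change in this assay. Putting methylsulfanyl in place of cyclopropyl on the aromatic carbon ortho to a hydroxy group gives a 3.6-fold lower number from compound 2 to compound 4 (0.56 log units; beyond the scatter), which shows that the plasma level depends on what this position carries, even though the rest of the molecule stays the same and the exchange alters only a small group. The three-membered ring of carbon leaves and a sulfur enters, yet nothing measured here explains why the number drops, so this single step records an outcome and not a mechanism.

One exchange cannot separate the loss of the ring from the arrival of the sulfur, and a methoxy group or an ethyl chain on the same carbon would help to tell these two apart. Among these compounds, it also remains open whether the same exchange would give a step of similar size on a different core, such as the one in compound 1, which has no sulfonyl group.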